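From 4-Fluorophenyl to 3-Bromophenyl in an Antiproliferative Series

The source may report more compounds than this note shows. Statements on the series, on what has been measured and on what is new or still open speak of the compounds shown alone.

In a functional assay on A549 cells (Homo sapiens) for antiproliferative activity, read by MTT assay, with a stated time of 72 h (a higher number here means a weaker inhibitor, a lower number a stronger inhibitor), compound 1 `NC1=NC2(CCOCC2)N(OCCCOc2ccc(F)cc2)C(N)=N1` gives 1060 nM, the higher of the two exact numbers available. Compound 2 `NC1=NC2(CCSCC2)N(OCCCOc2cccc(Cl)c2Cl)C(N)=N1` gives 1 nM, a far lower number, although its core differs from the core of compound 1. In this assay, compound 3 `NC1=NC2(CCSCC2)N(OCCCOc2cc(Cl)c(Cl)cc2Cl)C(N)=N1` is reported only as a limit, > 100000 nM.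

Compound 4 `NC1=NC2(CCOCC2)N(OCCCOc2cccc(Br)c2)C(N)=N1` departs from compound 1 in one group: 3-bromophenyl in place of 4-fluorophenyl on an oxygen on a saturated carbon. It carries 3-bromophenyl in place of 4-fluorophenyl on an oxygen on a saturated carbon. Among the compounds with values here, one measured step bears on this kind of exchange: an at least 100000-fold higher number from compound 2 to compound 3 (5.00 log units; beyond the scatter). That step ends at the limit of > 100000 nM in this assay, at which 1 of the 3 values shown sits, so its full size is not known. It shows that the phenyl group can shift the result enormously, but it was measured on a different core and with different substituents, so it cannot simply be carried over to compound 4. The low value of compound 2, 1 nM, tilts the expectation slightly downward, while compound 3 remains a warning that a large rise is possible. A moderate move toward a lower number is therefore expected, a 2.7-fold lower number from compound 1 to compound 4 (0.42 log units; beyond the scatter), with wide uncertainty. The estimated value for compound 4 is 400 nM, with an expected range from 30 nM to 5000 nM.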

Compound 4, half-maximal inhibitory concentration: 160 nM
For compound 4 the middle estimate is 2.5-fold (0.40 log units) above the measured one; the range from low to high includes it.
By their numbers in this assay, from the lowest: compound 2; then compound 4; then compound 1. At a limit, above all of these: compound 3.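

In this assay, the exchange on the shared core gives a 6.6-fold lower number from compound 1 to compound 4 (0.82 log units; beyond the scatter), the first step shown for this change of group with the core of compound 1 held fixed. Within the data shown here, the only earlier step at this place was measured on another core and ended at a limit for compound 3, so its full size stayed unknown, whereas this step has a full size and is modest. Since 3-bromophenyl differs from 4-fluorophenyl in both the halogen and where it sits on the ring, this single step cannot separate the two changes, and nothing measured here gives a reason for the lower number.

The compounds shown leave open whether 3-fluorophenyl or 4-bromophenyl on the core of compound 1 would tell the halogen apart from its place, and whether 3-bromophenyl would behave alike on the core of compound 2. They also leave open what an amine or a carboxylic acid on the phenyl ring, or a longer chain leading to it, would do in this series.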